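Replacing a hydroxy group with a hexyloxymethyl chain

The source may hold more compounds than are shown below. What is called first, only, known or untested is meant among the compounds shown, and "the series" means these compounds.

In a functional assay on MCF7 cells (Homo sapiens) for cytotoxicity, read by neutral red uptake, with a stated time of 3 days (on this read-out lower numbers stand for stronger inhibition and higher numbers for weaker inhibition), compound 1 `Nc1ccc(-c2cc(=O)c3c(N)c(F)c(O)c(F)c3o2)cc1F` gives > 10000 nM, which is a limit of the assay rather than a number. Compound 1 therefore stands at the limit of > 10000 nM in this assay, at which 1 of the 3 values shown sits. Compound 2 `COc1c(F)c(N)c2c(=O)cc(-c3ccc(N)c(F)c3)oc2c1F` gives 100 nM in this assay, and compound 3 `CN(C)CC(=O)OCc1c(F)c(N)c2c(=O)cc(-c3ccc(N)c(F)c3)oc2c1F` gives 26 nM. The step of an at least 100-fold lower number from compound 1 to compound 2 (2.00 log units; beyond the scatter) and the step of an at least 380-fold lower number from compound 1 to compound 3 (2.58 log units; beyond the scatter) both show that exchanging the hydroxy group of compound 1 for a group that carries no hydrogen-bond donor lowers the number sharply. Compound 4 `CCCCCCOCc1c(F)c(N)c2c(=O)cc(-c3ccc(N)c(F)c3)oc2c1F` carries (hexyloxy)methyl in place of hydroxy on an aromatic carbon. This change resembles the two measured steps in that the hydroxy group leaves and a group with no hydrogen-bond donor enters, so the same kind of large drop toward a lower number is expected. For compound 4 the expected step is an at least 160-fold lower number from compound 1 to compound 4 (2.22 log units; beyond the scatter), large and toward a lower number. Compound 4 is expected to give 60 nM in this assay, within a range from 15 nM to 400 nM.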

Compound 4, half-maximal inhibitory concentration: 7100 nM
Compound 4: the middle estimate sits 120-fold (2.07 log units) below what was measured; the measured number lies above the stated range.
By their numbers in this assay, from the lowest: compound 3; then compound 2; then compound 4. At a limit, above all of these: compound 1.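

At this aromatic carbon, the absence of a hydrogen-bond donor is not enough for a low number in this assay: the (hexyloxy)methyl group of compound 4 has no such donor, yet the measured steps are an at least 1.4-fold lower number from compound 1 to compound 4 (0.14 log units; that floor lies within the scatter), a 71-fold higher number from compound 2 to compound 4 (1.85 log units; beyond the scatter) and a 270-fold higher number from compound 3 to compound 4 (2.44 log units; beyond the scatter). The number here therefore depends on which group enters, not only on the hydroxy group leaving. Compound 1 stands at a limit of the assay and not at a number, so its step to compound 4 is a floor only, and that floor lies within the scatter: the limit of > 10000 nM in this assay, at which 1 of the 4 values shown sits.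

The compounds shown leave open how the number changes between the methoxy group and the (hexyloxy)methyl group, which a shorter chain such as propoxymethyl would help to place. They also leave open whether a hexyl chain ending in an amine would keep the high number of compound 4 or move toward the low number of compound 3.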